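Dropping the chloro from a sulfone urea activator

A few compounds are considered here, and "the series" means these few. Any claim that something is new, unique, unknown or untested is made for them only; others in the source may bear on it.

Measured so far:
compound 1, `O=C(NCc1ccncc1)Nc1ccc(S(=O)(=O)c2ccccc2Cl)cc1`: 79 nM
compound 2, `CCOC(=O)c1ccc(NC(=O)NCc2ccnnc2)cc1`: > 100000 nM
compound 3, `CCOC(=O)c1ccc(NC(=S)NCc2ccncc2)cc1`: 9770 nM

All three were tested in an assay on isolated protein for activation of Nicotinamide phosphoribosyltransferase (Homo sapiens); a lower number here means that less compound is needed, a higher number that more compound is needed for the effect. Compound 1, with its chlorinated sulfone arm, gives 79 nM in this assay, the lowest of the two numbers shown. Its nearest neighbour is compound 3, a thiourea bearing an ester, at 9770 nM, a gap that lies well beyond the scatter. Compound 2 sits at the limit of > 100000 nM in this assay, at which 1 of the 3 values shown sits; its value of > 100000 nM is a limit, not a number, so it does not join the comparison.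

Compound 4, `O=C(NCc1ccncc1)Nc1ccc(S(=O)(=O)c2ccccc2)cc1`, has not yet been measured. It differs from compound 1 in one place only: hydrogen in place of chloro on an aromatic carbon. Going by the values given here, no pair of measured compounds isolates such a change, so its effect has to be guessed from compound 1 alone. Because compound 1 is already at 79 nM, a modest rise in the number is expected, but nothing dramatic. The expected step is a 2.5-fold higher number from compound 1 to compound 4 (0.40 log units; beyond the scatter). Compound 4 is therefore estimated at 200 nM, with a range from 60 nM to 800 nM.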

Compound 4, half-maximal effective concentration: 85 nM
The estimate for compound 4 lay 2.4-fold (0.37 log units) above the measured number; measured number inside the range.
By their numbers in this assay, from the lowest: compounds 1 and 4 (each within the scatter of the next); then compound 3. At a limit, above all of these: compound 2.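

In this assay, the exchange of chloro for hydrogen gives a 1.1-fold higher number from compound 1 to compound 4 (0.03 log units; within the scatter) and that step lies within the scatter, so the 2-chlorophenyl and phenyl forms of the sulfone arm cannot be told apart. Going by these compounds alone, this is the first pair that isolates a single change, and it shows that, on an aromatic carbon ortho to a large group, the chlorine is not needed for a number in the range of compound 1: compound 4, which carries only hydrogen there, sits in that same range. Nothing shown gives a reason why the number holds at this position.

Going by these compounds, it remains open whether other groups at this same place, such as a methoxy group, an amine or a carboxylic acid, would also leave the number where it stands. A single pair also cannot tell whether the exchange of chloro for hydrogen would read the same way at another position on that ring or on a different core.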